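A few compounds are considered here, and "the series" means these few. Any claim that something is new, unique, unknown or untested is made for them only; others in the source may bear on it.

The measured compounds in an ADME assay on HEL cells (Homo sapiens) for cytotoxicity, read by microscopy; a higher number here means that more compound is tolerated, a lower number that less compound is tolerated:

Compound 1, `O=c1ccn(CCCCCOc2ccc(Br)cc2)c(=O)[nH]1`, gives 100000 nM.
Compound 2, `Nc1ccc(OCCCCCn2ccc(=O)[nH]c2=O)cc1`, is reported only as a limit of the assay, > 100000 nM.
Compound 3, `N#Cc1ccc(OCCCCCn2ccc(=O)[nH]c2=O)cc1`, gives 100000 nM.

Compound 3 stands level with compound 1 at the digits printed: the exchange of cyano for bromo brought no change at the digits printed from compound 1 to compound 3 (within the scatter). The value of compound 2 is a limit (the limit of > 100000 nM in this assay, at which 1 of the 3 values shown sits), so a number no lower from compound 1 to compound 2 (the limit leaves the size open) and a number no higher from compound 2 to compound 3 (the limit leaves the size open) leave their sizes open.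

Compound 4, `O=c1ccn(CCCCCOc2ccc([N+](=O)[O-])cc2)c(=O)[nH]1`, differs from compound 3 in one place: nitro in place of cyano on an aromatic carbon. Among the compounds with values here, no measured step exchanges a nitro group, so the expectation rests on the steps already seen at this aromatic carbon, which in this assay gave no change beyond the scatter or were open limits. Compound 4 is therefore expected to give no change at the digits printed from compound 3 to compound 4 (within the scatter), no change beyond the scatter. The estimate for compound 4 in this assay is 100000 nM, with a range from 50000 nM to 200000 nM.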

Compound 4, minimum cytotoxic concentration: 20000 nM
The estimate for compound 4 lay 5.0-fold (0.70 log units) above the measured number, and the stated range ends above it.
By their numbers in this assay, from the lowest: compound 4; then compounds 1 and 3 (each within the scatter of the next).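

In this assay, this aromatic carbon, where bromo, cyano and amino had shown no change beyond the scatter or only open limits, turned out not to be indifferent to what it carries: nitro in place of cyano gave a 5.0-fold lower number from compound 3 to compound 4 (0.70 log units; beyond the scatter). The same held against the other two groups, with nitro in place of bromo giving a 5.0-fold lower number from compound 1 to compound 4 (0.70 log units; beyond the scatter) and nitro in place of amino giving an at least 5.0-fold lower number from compound 2 to compound 4 (0.69 log units; beyond the scatter). The value of compound 2 behind that last step is a limit, not a number: the limit of > 100000 nM in this assay, at which 1 of the 4 values shown sits.

The compounds shown leave open whether this lower number belongs to nitro alone or would recur with a carboxylic acid or trifluoromethyl on the same carbon. They also leave open whether it would persist with a longer chain in place of the pentyl linker.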